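Aryl variation on the ring amide nitrogen: compound 4

A few compounds are considered here, and "the series" means these few. Any claim that something is new, unique, unknown or untested is made for them only; others in the source may bear on it.

The series shares one core, with the group on the amide-type nitrogen in the ring as the variable. Compound 1 `CC(C)N1C(=O)COc2ccc(-c3cccc(NS(=O)(=O)c4ccc(F)cc4)c3)cc21` carries isopropyl there and in a functional assay on HCT-116 cells (Homo sapiens) for antiproliferative activity, read by MTT assay, with a stated time of 72 h (a higher number here means a weaker inhibitor, a lower number a stronger inhibitor), compound 1 gives 22600 nM. Compound 2 `O=C1COc2ccc(-c3cccc(NS(=O)(=O)c4ccc(F)cc4)c3)cc2N1c1ccc(Cl)cc1` carries 4-chlorophenyl and compound 2 gives 23900 nM. Compound 3 `Cc1ccc(N2C(=O)COc3ccc(-c4cccc(NS(=O)(=O)c5ccc(F)cc5)c4)cc32)cc1` carries 4-methylphenyl and compound 3 gives 35600 nM. Compound 3 gives the highest of the three numbers, but the gaps are small: a 1.6-fold higher number from compound 1 to compound 3 (0.20 log units; within the scatter) and a 1.5-fold higher number from compound 2 to compound 3 (0.17 log units; within the scatter), both within the scatter, as is a 1.1-fold higher number from compound 1 to compound 2 (0.02 log units; within the scatter).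

Compound 4 `COc1cccc(N2C(=O)COc3ccc(-c4cccc(NS(=O)(=O)c5ccc(F)cc5)c4)cc32)c1` is the next member, with the change (3-methoxyphenyl in place of 4-methylphenyl on an amide-type nitrogen in a ring). All three measured steps bear on it, since each swaps the group on this nitrogen, and none moved the number beyond the scatter, isopropyl, 4-chlorophenyl and 4-methylphenyl giving much the same result. A further aryl variant is therefore expected to produce no step beyond the scatter in this assay, that is, a 1.2-fold lower number from compound 3 to compound 4 (0.07 log units; within the scatter) is expected. Compound 4 is estimated at 30000 nM, with a range from 12000 nM to 75000 nM.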

Compound 4, half-maximal inhibitory concentration: > 40000 nM
Compound 4 was reported as a limit; the forecaster's own chance of this, stated with the estimate: 10%; middle value at least 1.3-fold (0.12 log units) from the limit.
By their numbers in this assay, from the lowest: compounds 1, 2 and 3 (each within the scatter of the next). At a limit, above all of these: compound 4.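

In this assay compound 4 gives a limit and not a number: the limit of > 40000 nM in this assay, at which 1 of the 4 values shown sits. The three new steps are therefore floors only: an at least 1.1-fold higher number from compound 3 to compound 4 (0.05 log units; that floor lies within the scatter), an at least 1.6-fold higher number from compound 2 to compound 4 (0.22 log units; that floor lies within the scatter) and an at least 1.7-fold higher number from compound 1 to compound 4 (0.24 log units; that floor lies within the scatter), and none of them establishes a change beyond the scatter. For the compounds shown here, what is new is that 3-methoxyphenyl, the first group here with a hydrogen-bond acceptor, is also the first on this amide-type nitrogen without a measured number, so the flat picture from isopropyl, 4-chlorophenyl and 4-methylphenyl can be neither extended to it nor set aside.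

Going by these compounds, whether a chain ending in an amine or a carboxylic acid on this nitrogen would move the number beyond the scatter stays open. So does the true size of the step to 3-methoxyphenyl.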